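Adding a Methoxy Group to a Weak Cytotoxic Compound

A few compounds are considered here, and "the series" means these few. Any claim that something is new, unique, unknown or untested is made for them only; others in the source may bear on it.

Compound 1 `COc1ccc(-c2nnc(COc3ccc(C#N)cc3OC)o2)cc1`: 13000 nM
Compound 2 `c1ccc(-c2nnc(COc3ccc(-c4nnco4)cc3)o2)cc1`: > 50000 nM

In a functional assay on MDA-MB-453 cells (Homo sapiens) for cytotoxicity, read by MTT assay, with a stated time of 48 h (a lower number here means a stronger inhibitor, a higher number a weaker inhibitor), compound 2 gives > 50000 nM, which is a limit of the assay and not a number. Compound 3 `COc1ccc(-c2nnc(COc3ccc(-c4nnco4)cc3)o2)cc1` makes one change to compound 2: methoxy in place of hydrogen on an aromatic carbon, turning phenyl to 4-methoxyphenyl. Among the measured compounds shown here, no measured step isolates this change. Compound 1 also carries 4-methoxyphenyl and gives 13000 nM, but it differs elsewhere, so it is only a loose guide. A modest gain toward stronger inhibition is expected, with the estimated at least 1.7-fold lower number from compound 2 to compound 3 (0.25 log units; that floor lies within the scatter). For compound 3 the estimated value is 28000 nM, within a range of 9000 nM to 50000 nM.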

Compound 3, half-maximal inhibitory concentration: 36200 nM
Compound 3: the middle estimate sits 1.3-fold (0.11 log units) below what was measured; low and high end bracket the measured number.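

Methoxy in place of hydrogen on an aromatic carbon gives an at least 1.3-fold lower number from compound 2 to compound 3 (0.14 log units; that floor lies within the scatter) and so puts a number rather than a limit on this core in this assay for compound 3. The floor of that step does not by itself show a real gain at this place, para to a large group. Compound 2 has only a limit of the assay, so the full size of the step stays unread: the limit of > 50000 nM in this assay, at which 1 of the 3 values shown sits.

From the compounds shown here alone, whether a hydroxyl, an ethoxy group or an amine at this place would give a lower number stays open.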